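The compounds below may be only part of what the source reports. "The series", "measured", "known", "first", "only" and "open" are said of these compounds alone.

Measured so far:
compound 1, `Cc1cc(C)c(NC(=O)N(Cc2cccc(-c3nn[nH]n3)c2)C2CCCCCC2)c(C)c1` — > 1000 nM
compound 2, `Cc1cc(C)c(NC(=O)N(Cc2ccc(-c3cccs3)cc2)C2CCCCCC2)c(C)c1` — 22 nM

In an assay on microsomes from intestine for inhibition of acyl-CoA:cholesterol acyltransferase (Oryctolagus cuniculus) (on this read-out higher numbers stand for weaker inhibition and lower numbers for stronger inhibition), compound 1 gives only a limit, > 1000 nM, and no number. Compound 1 thus stands at the limit of > 1000 nM in this assay, at which 1 of the 2 values shown sits. Compound 2 sits at 22 nM in this assay. The two measured compounds do not differ in one place only, so no measured step size is at hand from them.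

Compound 3, `Cc1cc(C)c(NC(=O)N(Cc2cccc(-c3cn[nH]c3)c2)C2CCCCCC2)c(C)c1`, is next to be measured. Relative to compound 1 it carries 1H-pyrazol-4-yl in place of 2H-tetrazol-5-yl on an aromatic carbon, that is, 1H-pyrazol-4-yl in place of 2H-tetrazol-5-yl on an aromatic carbon. With compound 1 known only as a limit in this assay, the step from it can only be judged against that limit. The step of an at least 3.3-fold lower number from compound 1 to compound 3 (0.52 log units; beyond the scatter) is expected to go toward stronger inhibition, beyond the usual scatter. For compound 3 the estimate in this assay is 300 nM, with a range from 80 nM to 1500 nM.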

Compound 3, half-maximal inhibitory concentration: 38 nM
For compound 3 the middle estimate is 7.9-fold (0.90 log units) above the measured one; the whole stated range lies above it.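

In this assay, the place on an aromatic carbon meta to a large group proves sensitive to the identity of the five-membered aromatic ring, with 1H-pyrazol-4-yl in place of 2H-tetrazol-5-yl giving an at least 26-fold lower number from compound 1 to compound 3 (1.42 log units; beyond the scatter). The change keeps the heavy-atom and hydrogen-bond donor counts but has fewer hetero atoms and hydrogen-bond acceptors, so strong inhibition at this place does not rule out a ring bearing a hydrogen-bond donor. Compound 1 is held only at a limit, so this step is a bound and its full size is unknown: the limit of > 1000 nM in this assay, at which 1 of the 3 values shown sits.

The two rings shown do not separate the contributions of the ring nitrogens, the acceptor count and the ring's hydrogen-bond donor. On these data alone, how a 1-methylpyrazol-4-yl, a plain phenyl or a carboxylic acid at this place would read out remains open.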